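Changing the carbonyl group on compound 2

This account rests on a few compounds, and the source may have more. Where it says the series, first, only, none or still open, it means among the compounds named here.

In a functional assay on NB1 cells (Homo sapiens) for antiproliferative activity, with a stated time of 72 h (a higher number here means a weaker inhibitor, a lower number a stronger inhibitor), compound 2 (`Cc1cc(C)cc(C(=O)N(CCC(=O)NCc2ccccc2)Cc2ccc(C(=O)NO)cc2)c1`) gives 3870 nM and is the weakest of three measured compounds. The others are compound 1 (`Cc1ccc(NC(=O)CCN(Cc2ccc(C(=O)NO)cc2)C(=O)c2cc(C)cc(C)c2)cc1`) at 670 nM and compound 3 (`CN(C)c1ccc(C(=O)N(CCC(=O)NCc2ccc(Cl)cc2)Cc2ccc(C(=O)NO)cc2)cc1`) at 850 nM in the same test. Compound 4 (`COc1ccc(C(=O)N(CCC(=O)NCc2ccccc2)Cc2ccc(C(=O)NO)cc2)cc1`) carries 4-methoxyphenyl in place of 3,5-dimethylphenyl on a carbonyl carbon and otherwise matches compound 2. Going by the values given here, the only measured single-place step, a 5.8-fold higher number from compound 1 to compound 2 (0.76 log units; beyond the scatter) for benzyl in place of 4-methylphenyl on an amide-type nitrogen, was modest but lies elsewhere in the molecule. Among the compounds with values here, no measured step touches this carbonyl group, so none gives a size to carry over. The expected result is a 1.4-fold lower number from compound 2 to compound 4 (0.14 log units; within the scatter) in this assay (no step beyond the scatter). The estimated value for compound 4 is 2800 nM (expected range 1100 nM to 7000 nM).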

Compound 4, half-maximal inhibitory concentration: 2520 nM
The estimate for compound 4 lay 1.1-fold (0.05 log units) above the measured number; low and high end bracket the measured number.
By their numbers in this assay, from the lowest: compounds 1 and 3 (each within the scatter of the next); then compounds 4 and 2 (each within the scatter of the next).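

Replacing the aryl group on this carbonyl carbon gives a 1.5-fold lower number from compound 2 to compound 4 (0.19 log units; within the scatter) in this assay and stays within the scatter, so 4-methoxyphenyl and 3,5-dimethylphenyl cannot be told apart here. This holds even though 4-methoxyphenyl brings a hydrogen-bond acceptor that 3,5-dimethylphenyl lacks. No measurement shown explains this result. Still open, on these data alone, is whether a phenyl ring carrying an amine or a carboxylic acid, or a cyclohexyl group without an aromatic ring, would shift the number at this carbonyl.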